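A few compounds are considered here, and "the series" means these few. Any claim that something is new, unique, unknown or untested is made for them only; others in the source may bear on it.

In a functional assay on NB1 cells (Homo sapiens) for cytotoxicity, read by MTT assay, with a stated time of 3 days (on this read-out lower numbers stand for stronger inhibition and higher numbers for weaker inhibition), three compounds built on one shared core give closely matched numbers: compound 1 `N#Cc1c(Cl)nc(SCc2nc3ccccc3[nH]2)nc1-c1ccccc1` gives 2.87 nM, compound 2 `N#Cc1c(Nc2ccccc2)nc(SCc2nc3ccccc3[nH]2)nc1-c1ccccc1` gives 2.5 nM and compound 3 `N#Cc1c(Nc2nccs2)nc(SCc2nc3ccccc3[nH]2)nc1-c1ccccc1` gives 3.2 nM. Compound 3 therefore lies within the scatter of both others. Compound 4 `N#Cc1c(NC(N)=O)nc(SCc2nc3ccccc3[nH]2)nc1-c1ccccc1` carries carbamoyl in place of 1,3-thiazol-2-yl on a nitrogen on an aromatic ring. Three measured steps change the same place on the core: a 1.1-fold lower number from compound 1 to compound 2 (0.06 log units; within the scatter), a 1.1-fold higher number from compound 1 to compound 3 (0.05 log units; within the scatter) and a 1.3-fold higher number from compound 2 to compound 3 (0.11 log units; within the scatter). All three stayed within the scatter, but none of them involved a ureido group, so the range must stay generous. No step beyond the scatter is therefore expected in this assay. The estimated step is a 1.1-fold lower number from compound 3 to compound 4 (0.03 log units; within the scatter). The expected value for compound 4 is 3 nM, with an estimated range of 1.2 nM to 9 nM.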

Compound 4, half-maximal inhibitory concentration: 7.35 nM
Estimate against measurement, compound 4: 2.5-fold (0.39 log units) below; low and high end bracket the measured number.
By their numbers in this assay, from the lowest: compounds 2, 1 and 3 (each within the scatter of the next); then compound 4.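

Ureido stands apart in this assay with three modest steps beyond the scatter: a 2.3-fold higher number from compound 3 to compound 4 (0.36 log units; beyond the scatter) and a 2.9-fold higher number from compound 2 to compound 4 (0.47 log units; beyond the scatter) and a 2.6-fold higher number from compound 1 to compound 4 (0.41 log units; beyond the scatter) at this one position. So this position does not accept every group alike, although chloro, anilino and (1,3-thiazol-2-yl)amino gave numbers within the scatter of each other. No measurement shown here explains the shift. From the compounds shown here alone, it remains open whether a plain amine or an acetylamino group would stay with those three or follow ureido. Going by these compounds, whether the shift holds in other cell lines also remains open.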